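The compounds below may be only part of what the source reports. "The series", "measured", "known", "first", "only" and "open" are said of these compounds alone.

Of the compounds shown here, two built on one shared core have so far been measured in a functional assay on ECa-109 cells for inhibition, with ECa-109 cell line (Homo sapiens) as the target, read by sulforhodamine B assay; on this read-out lower numbers stand for stronger inhibition and higher numbers for weaker inhibition. Compound 1 `O=C1C(Nc2cccc(Cl)c2)=CC(=O)c2c1nc1n2[C@H]2OC[C@@H](O)[C@H]2OC1` gives 3080 nM. Compound 2 `O=C1C(Nc2ccccc2)=CC(=O)c2c1nc1n2[C@H]2OC[C@@H](O)[C@H]2OC1` gives 3560 nM. Among the two numbers, compound 2 stands with the higher one, and its nearest neighbour is compound 1; the single recorded step, a 1.2-fold higher number from compound 1 to compound 2 (0.06 log units; within the scatter), falls within the scatter, so the two values sit together rather than apart. Compound 3 `O=C1C(Nc2ccccc2F)=CC(=O)c2c1nc1n2[C@H]2OC[C@@H](O)[C@H]2OC1` has not yet been measured. It differs from compound 2 by fluoro in place of hydrogen on an aromatic carbon, set on an aromatic carbon of the six-membered aromatic ring of carbon only, ortho to a large group. Within the data shown here, the only step that bears on this change is a 1.2-fold higher number from compound 1 to compound 2 (0.06 log units; within the scatter), hydrogen in place of chloro on an aromatic carbon of the same ring, and it stayed inside the scatter. A fluoro entering that ring is therefore expected to leave this assay largely as it is, and the step of a 1.1-fold lower number from compound 2 to compound 3 (0.03 log units; within the scatter) is expected to remain within the scatter. Compound 3 is estimated at 3300 nM, with a range from 1500 nM to 7500 nM.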

Compound 3, half-maximal inhibitory concentration: 2660 nM
For compound 3 the middle estimate is 1.2-fold (0.09 log units) above the measured one, and the stated range covers the measured number.
By their numbers in this assay, from the lowest: compounds 3, 1 and 2 (each within the scatter of the next).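

In this assay, compound 3 carries fluoro ortho to a large group, on a carbon of the ring that bears only hydrogen in compounds 1 and 2, and this change gives a 1.3-fold lower number from compound 2 to compound 3 (0.13 log units; within the scatter), so the assay does not separate fluoro from hydrogen at this place. The exchange of 3-chlorophenyl for 2-fluorophenyl on the amine nitrogen gives a 1.2-fold lower number from compound 1 to compound 3 (0.06 log units; within the scatter), which means that phenyl, 3-chlorophenyl and 2-fluorophenyl now all sit together, and none of the three compounds goes against this. Nothing at hand accounts for these values or for their closeness.

On these data alone, whether a larger group at this same carbon, such as methoxy or trifluoromethyl, or an amine or a carboxylic acid elsewhere on the ring, would carry the number beyond the scatter remains open. The compounds shown differ only on this ring, so they also leave open how the number would respond to a change on the shared core, for instance at its hydroxyl group.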